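The source may report more compounds than this note shows. Statements on the series, on what has been measured and on what is new or still open speak of the compounds shown alone.

Compound 1 `CC(C)(C)c1cc(-c2cc(=O)c3ccc(OCc4ccc5ccccc5n4)cc3o2)cc(C(C)(C)C)c1O` carries the (quinolin-2-yl)methoxy group on the shared core. In a functional assay for inhibition (a lower number here means a stronger inhibitor, a higher number a weaker inhibitor), compound 1 gives 3000 nM, the highest of the three numbers measured. Compound 2 `CN(C)CCCOc1ccc2c(=O)cc(-c3cc(C(C)(C)C)c(O)c(C(C)(C)C)c3)oc2c1` gives 700 nM in this assay, and compound 3 `CC(C)(C)c1cc(-c2cc(=O)c3ccc(O)cc3o2)cc(C(C)(C)C)c1O` gives 1000 nM. Both measured changes at this oxygen lower the number: a 4.3-fold lower number from compound 1 to compound 2 (0.63 log units; beyond the scatter) and a 3.0-fold lower number from compound 1 to compound 3 (0.48 log units; beyond the scatter). Between compound 2 and compound 3 the difference is a 1.4-fold higher number from compound 2 to compound 3 (0.15 log units; within the scatter).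

Compound 4 `CC(C)(C)c1cc(-c2cc(=O)c3ccc(OCC(O)CO)cc3o2)cc(C(C)(C)C)c1O` is not yet measured; relative to compound 1 the change is 1,2-dihydroxyethyl in place of quinolin-2-yl on a saturated chain carbon bound to an oxygen on an aromatic ring. The two steps that bear on it are the ones that start from compound 1; each replaces the quinolin-2-yl at the same place, and each was modest and toward a lower number. A step of similar size, toward a lower number, is therefore expected in this assay for compound 4, estimated as a 3.8-fold lower number from compound 1 to compound 4 (0.57 log units; beyond the scatter). The number expected for compound 4 is 800 nM, with a range from 300 nM to 2500 nM.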

Compound 4, half-maximal inhibitory concentration: 100 nM
Beside the measured number, compound 4's estimate is 8.0-fold (0.90 log units) above it; the whole stated range lies above it.
By their numbers in this assay, from the lowest: compound 4; then compounds 2 and 3 (each within the scatter of the next); then compound 1.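

In this assay, going by these compounds alone, the 2,3-dihydroxypropyl group gives the only large step seen at this oxygen on an aromatic ring (a 30-fold lower number from compound 1 to compound 4 (1.48 log units; beyond the scatter)). The step also clears both earlier reference points (a 10-fold lower number from compound 3 to compound 4 (1.00 log units; beyond the scatter); a 7.0-fold lower number from compound 2 to compound 4 (0.85 log units; beyond the scatter)), so the number at this position is no longer confined to the level of compounds 2 and 3, which lie within the scatter of each other. Against the free hydroxyl of compound 3, substitution on this oxygen now moves the number both ways: upward with (quinolin-2-yl)methyl in compound 1 and downward with 2,3-dihydroxypropyl in compound 4, and nothing measured here accounts for the size of the drop.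

Going by these compounds, whether both hydroxyl groups of the chain are needed remains open, and a 2-hydroxyethyl or 2-methoxyethyl group would test this. A carboxylic acid or a longer diol chain on the same oxygen would show how far the step extends beyond compound 4.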